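This account rests on a few compounds, and the source may have more. Where it says the series, first, only, none or still open, it means among the compounds named here.

Compound 2 `COc1cccc(-c2cc(C(=O)Nc3ccc(Oc4ccnc5cc(OCCCN6CCCCC6)c(OC)cc45)c(F)c3)c3cc(F)ccc3n2)c1` gives 1000 nM in a functional assay on NCI-H460 cells (Homo sapiens) for cytotoxicity, read by MTT assay, with a stated time of 72 h (a lower number here means a stronger inhibitor, a higher number a weaker inhibitor), the highest of the two numbers recorded so far. Its nearest neighbour, compound 1 `COc1cccc(-c2cc(C(=O)Nc3ccc(Oc4ccnc5cc(OCCCN6CCCCC6)c(OC)cc45)c(F)c3)c3ccccc3n2)c1`, gives 210 nM in this assay. Within the data shown here, the only measured step, a 4.8-fold higher number from compound 1 to compound 2 (0.68 log units; beyond the scatter), places a fluoro in place of hydrogen on an aromatic carbon and is the sole change in the set that moves the number.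

Compound 3 `COc1cc2c(Oc3ccc(NC(=O)c4cc(-c5ccc(Cl)cc5Cl)nc5ccc(F)cc45)cc3F)ccnc2cc1OCCCN1CCCCC1` has not yet been measured. It differs from compound 2 by 2,4-dichlorophenyl in place of 3-methoxyphenyl on an aromatic carbon, a 2,4-dichlorophenyl in place of 3-methoxyphenyl on an aromatic carbon of a six-membered aromatic ring with one nitrogen, part of a fused system of two rings. Among the measured compounds shown here, no measured step concerns this group or this kind of exchange; the fluoro-for-hydrogen step lies elsewhere on the shared core and offers no guide to the direction here. The step in this assay that this implies is expected to be a 1.1-fold higher number from compound 2 to compound 3 (0.04 log units; within the scatter), carrying a wide uncertainty. Compound 3 is therefore estimated to give about 1100 nM, between 350 nM and 3500 nM.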

Compound 3, half-maximal inhibitory concentration: 310 nM
Compound 3: middle estimate off by 3.5-fold (0.55 log units), on the high side, and the stated range ends above it.
By their numbers in this assay, from the lowest: compounds 1 and 3 (each within the scatter of the next); then compound 2.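

In this assay, the group on the aromatic carbon next to the ring nitrogen proves able to move the number: a 3.2-fold lower number from compound 2 to compound 3 (0.51 log units; beyond the scatter) is a step beyond the scatter, and it runs in the opposite direction to the earlier fluoro-for-hydrogen exchange elsewhere on the shared core. The exchange happens with the heavy-atom count unchanged, since 3-methoxyphenyl and 2,4-dichlorophenyl each hold 8 heavy atoms, so the gain in potency goes with a different set of atoms on the ring rather than a larger group, the oxygen of the methoxy giving way to two chlorines. Nothing available explains why this exchange lowers the number.

The compounds shown leave open whether 2,4-dichlorophenyl would give a similar step on the core without the fluoro of compound 2, since only one such exchange can be read here. They also leave open which part of the change carries the step, and how a plain phenyl, a chlorophenyl with one chlorine, or a pyridine ring would behave at this position.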